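The compounds below may be only part of what the source reports. "The series", "measured", "known", "first", "only" and "open" are said of these compounds alone.

Among the three compounds measured so far, compound 3 `C=CC(=O)Nc1cccc(Nc2nc(N/N=C(\C)c3ccc(F)cc3F)ncc2Cl)c1` gives the lowest number in an ADME assay on HT-29 cells (Homo sapiens) for inhibition, read by MTT assay, with a stated time of 72 h (a lower number here means a stronger inhibitor, a higher number a weaker inhibitor), namely 4360 nM. Compound 2 `C=CC(=O)Nc1cccc(Nc2nc(N/N=C/c3cn(Cc4ccccc4)c4ccccc34)ncc2Cl)c1` gives 11000 nM and compound 1 `Nc1cccc(Nc2nc(N/N=C/c3ccc(F)cc3)ncc2Cl)c1` gives 12300 nM; both gaps to compound 3 lie beyond the usual scatter. Compound 4 `C=CC(=O)Nc1cccc(Nc2nc(N/N=C(\C)c3ccncc3)ncc2Cl)c1` has not been measured yet. It differs from compound 3 by pyridin-4-yl in place of 2,4-difluorophenyl on a carbon with a double bond to nitrogen. Within the data shown here, no pair of measured compounds differs only in this way, so there is no measured step to lean on, and the expectation rests on compound 3 alone. The change is expected to amount to a 1.4-fold higher number from compound 3 to compound 4 (0.14 log units; within the scatter), a shift no larger than the scatter, with a slightly weaker result somewhat more likely than a stronger one. Compound 4 is therefore expected to give 6000 nM, with a plausible range from 2500 nM to 15000 nM.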

Compound 4, half-maximal inhibitory concentration: 12800 nM
Estimate against measurement, compound 4: 2.1-fold (0.33 log units) below; the range from low to high includes it.
By their numbers in this assay, from the lowest: compound 3; then compounds 2, 1 and 4 (each within the scatter of the next).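

In this assay, among these compounds, replacing 2,4-difluorophenyl with pyridin-4-yl on the carbon with a double bond to nitrogen gives a 2.9-fold higher number from compound 3 to compound 4 (0.47 log units; beyond the scatter) and so provides the first measured step at this position. It shows that the ring held there can change the result, and that this swap moves toward weaker inhibition. No measurement shown explains the rise.

This single swap removes both fluorines and adds a ring nitrogen, and the two changes cannot be separated here. A plain phenyl or a pyridin-3-yl at this position remains an open comparison.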